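This account rests on a few compounds, and the source may have more. Where it says the series, first, only, none or still open, it means among the compounds named here.

Compound 1 `Cc1ccnc(/C(N)=N/NC(=S)N2CCOCC2)c1`, compound 2 `Cc1ccnc(/C(N)=N/NC(=S)N2CCSCC2)c1` and compound 3 `Cc1ccnc(/C(N)=N/NC(=S)N2CCCCC2)c1` share one core and differ only in the group attached to the thiocarbonyl carbon. In a functional assay on A-431 cells (Homo sapiens) for cytotoxicity, read by MTT assay, with a stated time of 72 h, tested at 3 uM (a higher number here means more inhibition of growth at the concentration tested, a lower number less inhibition of growth), compound 1 gives 35.5%, compound 2 gives 34.7% and compound 3 gives 36.5%. Compound 3 carries the highest of the three numbers, but its nearest neighbour is compound 1 and its furthest is compound 2, and both gaps fall within the scatter, so the three compounds cannot be told apart on these measurements.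

Compound 4 `Cc1ccnc(/C(N)=N/NC(=S)N2CCCC2)c1` continues the same series: pyrrolidin-1-yl in place of piperidin-1-yl on a thiocarbonyl carbon. The measured steps that bear on this change are the earlier exchanges of one ring for another on the same thiocarbonyl carbon: a number 0.8 percentage points lower from compound 1 to compound 2 (within the scatter), a number 1 percentage points higher from compound 1 to compound 3 (within the scatter) and a number 1.8 percentage points higher from compound 2 to compound 3 (within the scatter). Each of these moved this assay by less than the scatter, so replacing one six-membered non-aromatic ring with another at this position has so far made no visible difference. A further exchange, this time to a five-membered non-aromatic ring, is therefore expected to give no step beyond the scatter, and the expected step is a number 0.5 percentage points lower from compound 3 to compound 4 (within the scatter). Compound 4 is accordingly estimated at 36%, within a range from 26% to 46%.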

Compound 4, percent growth inhibition at one concentration: 63%
Compound 4: the middle estimate sits 27 percentage points below what was measured; measured number above the stated range.
By their numbers in this assay, from the lowest: compounds 2, 1 and 3 (each within the scatter of the next); then compound 4.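

The ring on the thiocarbonyl carbon turns out to matter in this assay: the three six-membered rings could not be told apart, yet the five-membered pyrrolidin-1-yl stands clear of each of them. Placed in exchange for piperidin-1-yl, it gives the step (a number 26.5 percentage points higher from compound 3 to compound 4 (beyond the scatter)); in exchange for thiomorpholin-4-yl, the step (a number 28.3 percentage points higher from compound 2 to compound 4 (beyond the scatter)); and in exchange for morpholin-4-yl, the step (a number 27.5 percentage points higher from compound 1 to compound 4 (beyond the scatter)). All three steps lie beyond the scatter and are close in size, so within these four compounds the result sets compound 4 apart from the whole group, and no information is available on what lies behind the difference.

Going by these compounds alone, with only one five-membered ring in the set, these compounds cannot show whether ring size itself is what counts or whether something particular to pyrrolidin-1-yl is responsible. As far as these compounds go, the four-membered azetidin-1-yl, the seven-membered azepan-1-yl, an open-chain dimethylamino group or a pyrrolidin-1-yl ring bearing a hydroxyl group would each test this further, and the shape of the trend across such groups remains open.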